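Thiophen-3-yl Replaced by 1-Benzofuran-2-yl in Compound 4

The source may hold more compounds than are shown below. What is called first, only, known or untested is meant among the compounds shown, and "the series" means these compounds.

Compound 1 `COc1ncnc2c1c(-c1ccsc1)cn2[C@@H]1O[C@H](CO)[C@@H](O)[C@H]1O`: 2570 nM in a functional assay on CCRF-CEM cells (Homo sapiens), read by MTT assay, with a stated time of 72 h; on this read-out lower numbers stand for stronger inhibition and higher numbers for weaker inhibition
Compound 2 `CN(C)c1ncnc2c1c(-c1ccsc1)cn2[C@@H]1O[C@H](CO)[C@@H](O)[C@H]1O`: 3480 nM
Compound 3 `CSc1ncnc2c1c(-c1ccsc1)cn2[C@@H]1O[C@H](CO)[C@@H](O)[C@H]1O`: only the limit > 20000 nM was reached

In this assay compound 1 holds the lowest of the two numbers given, with compound 2 nearest: the step of a 1.4-fold higher number from compound 1 to compound 2 (0.13 log units; within the scatter). Compound 3 stands apart, since an at least 7.7-fold higher number from compound 1 to compound 3 (0.89 log units; beyond the scatter) and an at least 5.7-fold higher number from compound 2 to compound 3 (0.75 log units; beyond the scatter), both resting on (the limit of > 20000 nM in this assay, at which 1 of the 3 values shown sits). All three measured steps change only the group on one aromatic carbon and leave the thiophen-3-yl untouched.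

Compound 4 `COc1ncnc2c1c(-c1cc3ccccc3o1)cn2[C@@H]1O[C@H](CO)[C@@H](O)[C@H]1O` differs from compound 1 by 1-benzofuran-2-yl in place of thiophen-3-yl on an aromatic carbon. For the measured compounds named here, no measured step bears on this change, so the expectation rests on compound 1 alone and carries a wide range. Compound 4 is expected to give about 3000 nM, between 700 nM and 13000 nM, meaning an estimated step of a 1.2-fold higher number from compound 1 to compound 4 (0.07 log units; within the scatter).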

Compound 4, half-maximal inhibitory concentration: 5370 nM
Beside the measured number, compound 4's estimate is 1.8-fold (0.25 log units) below it; the measured number falls inside the stated range.
By their numbers in this assay, from the lowest: compounds 1, 2 and 4 (each within the scatter of the next, the first and the last beyond it). At a limit, above all of these: compound 3.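

For the compounds shown here, with the methoxy group held in place, the change at this aromatic carbon from thiophen-3-yl to 1-benzofuran-2-yl gives a 2.1-fold higher number from compound 1 to compound 4 (0.32 log units; beyond the scatter) in this assay and is the first measured change of this group. The added six-membered aromatic ring therefore shifts the number only modestly, and compound 4 still gives a measured value rather than a limit. Nothing given here accounts for the step.

Going by these compounds, whether a phenyl or a furan-2-yl at this carbon would give a lower number remains open. So does whether 1-benzofuran-2-yl would act alike with dimethylamino or methylsulfanyl on the shared core.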